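The source may report more compounds than this note shows. Statements on the series, on what has been measured and on what is new or still open speak of the compounds shown alone.

Compounds measured in a functional assay on MGC-803 cells (Homo sapiens) for antiproliferative activity, read by CCK-8 assay, with a stated time of 72 h, tested at 8 uM; a lower number here means a weaker effect, a higher number a stronger effect of the compound at the concentration tested:
compound 1 `Nc1ccccc1NC(=O)c1ccc(CSC(=S)N2CCN(c3cccnc3)CC2)cc1` — 76.9%
compound 2 `Nc1ccccc1NC(=O)c1ccc(CSC(=S)N2CCc3cc(Cl)ccc32)cc1` — 82.2%
compound 3 `CC1CCCCN1C(=S)SCc1ccc(C(=O)Nc2ccccc2N)cc1` — 86.9%

The three numbers lie within the usual scatter of one another, so the values of compound 1, compound 2 and compound 3 cannot be told apart with confidence. Compound 4 `Nc1ccccc1NC(=O)c1ccc(CSC(=S)N2CCN(Cc3ccccc3)CC2)cc1` differs from compound 1 in one place: benzyl in place of pyridin-3-yl on an amine nitrogen in a ring. Within the data shown here, the only measured step, a number 4.7 percentage points higher from compound 2 to compound 3 (within the scatter), changes the group on the thiocarbonyl carbon, not the group on the ring nitrogen, and is itself within the scatter; no measured step touches the place changed here. With no guidance pointing either way, the step of a number 3.1 percentage points higher from compound 1 to compound 4 (within the scatter) is expected to stay within the scatter. The value of compound 4 in this assay is therefore estimated at 80%, with a likely range from 66% to 92%.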

Compound 4, a percentage reported as inhibition, at one concentration (the size of the read-out at that concentration, not a potency): 19.7%
Estimate against measurement, compound 4: 60.3 percentage points above; the measured number lies below the stated range.
By their numbers in this assay, from the lowest: compound 4; then compounds 1, 2 and 3 (each within the scatter of the next).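

Benzyl in place of pyridin-3-yl on the amine nitrogen in the ring gives a number 57.2 percentage points lower from compound 1 to compound 4 (beyond the scatter) in this assay. This shows that the activity at the tested concentration can depend strongly on this position, which the earlier step, made at a different place, could not reveal. Nothing available explains the drop.

The change alters both the aromatic ring and its attachment, and these compounds do not separate the two. Phenyl or pyridin-3-ylmethyl on the same nitrogen would show which of them goes with the lower number.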